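Trifluoromethyl addition to the fluorophenyl pyrrolidine acid

This account rests on a few compounds, and the source may have more. Where it says the series, first, only, none or still open, it means among the compounds named here.

Of the compounds shown here, two have numbers so far. Compound 1 `O=C(O)C1CCN(c2ccccc2F)C1` in an assay on cells for inhibition of Palmitoleoyl-protein carboxylesterase NOTUM variant C330S (Homo sapiens), read by fluorescence, with a stated time of 40 min (on this read-out lower numbers stand for stronger inhibition and higher numbers for weaker inhibition), gives 11000 nM. Compound 2 `O=C(O)C1CCN(c2ccccc2Cl)C1` in this assay gives 19000 nM. Among the compounds with values here, the single measured step, a 1.7-fold higher number from compound 1 to compound 2 (0.24 log units; within the scatter), stays within the scatter, so compound 1 holds the lowest of the two numbers without standing apart from compound 2.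

Compound 3 `O=C(O)C1CCN(c2cccc(C(F)(F)F)c2F)C1` differs from compound 1 by trifluoromethyl in place of hydrogen on an aromatic carbon, ortho to a fluoro group. Within the data shown here, no measured step covers such an addition; the one step in hand, a halogen exchange, is of another kind and bore no change beyond the scatter. Nothing in the numbers therefore supports a large step in either direction in this assay, and a modest move at most is expected, a 1.8-fold lower number from compound 1 to compound 3 (0.26 log units; within the scatter). Compound 3 is estimated at 6000 nM, with a range from 1500 nM to 20000 nM.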

Compound 3, half-maximal inhibitory concentration: 6800 nM
Compound 3: the middle estimate sits 1.1-fold (0.05 log units) below what was measured; low and high end bracket the measured number.
By their numbers in this assay, from the lowest: compounds 3, 1 and 2 (each within the scatter of the next, the first and the last beyond it).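

In this assay, trifluoromethyl in place of hydrogen on the aromatic carbon ortho to a fluoro group gives a 1.6-fold lower number from compound 1 to compound 3 (0.21 log units; within the scatter), so compound 1 and compound 3 cannot be told apart. The earlier step covered only an exchange of one halogen for another, whereas this one shows that an aromatic carbon carrying hydrogen in compound 1 can take a group of 4 heavy atoms with the number staying within the scatter. No measurement is at hand that bears on this result.

The compounds shown leave open whether a methyl, a nitrile or an amine on this same carbon would give a step beyond the scatter. They also leave open what an amide in place of the carboxylic acid would do in this series.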